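Swapping a fluoropyridine for a fluorophenyl: dog clearance

A few compounds are considered here, and "the series" means these few. Any claim that something is new, unique, unknown or untested is made for them only; others in the source may bear on it.

Compound 1 `COc1ccc(CNC(=O)c2cc(-c3cncc(C)c3)ncc2-c2cncc(F)c2)nc1OC` was tested in an ADME assay on the whole organism for pharmacokinetics, with Canis familiaris (Canis lupus familiaris) as the target, using cassette dosing (a higher number here means faster removal of the compound, a lower number slower removal), and gives 19 mL/min/kg. That is the lower of the two numbers in hand; compound 2 `COc1ccc(CNC(=O)c2nc(-c3cncc(C)c3)ncc2-c2ccccc2)nc1OC` gives 47 mL/min/kg in this assay, a gap beyond the usual scatter, though the two also differ in their shared core, so the gap cannot be tied to any one change. Compound 3 `COc1ccc(CNC(=O)c2cc(-c3cncc(C)c3)ncc2-c2ccccc2F)nc1OC` has not yet been measured in this assay. It differs from compound 1 in one place: 2-fluorophenyl in place of 5-fluoropyridin-3-yl on an aromatic carbon, on an aromatic carbon of a six-membered aromatic ring with 1 nitrogen. Within the data shown here, no pair of measured compounds isolates this kind of change, so the size of the step is uncertain. Compound 3 is expected to clear somewhat faster than compound 1, an estimated step of a 1.6-fold higher number from compound 1 to compound 3 (0.20 log units; within the scatter) in this assay. For compound 3 the estimate in this assay is 30 mL/min/kg, with a likely range from 15 mL/min/kg to 60 mL/min/kg.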

Compound 3, clearance: 17 mL/min/kg
For compound 3 the middle estimate is 1.8-fold (0.25 log units) above the measured one; low and high end bracket the measured number.
By their numbers in this assay, from the lowest: compounds 3 and 1 (each within the scatter of the next); then compound 2.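

In this assay, putting 2-fluorophenyl in place of 5-fluoropyridin-3-yl gives a 1.1-fold lower number from compound 1 to compound 3 (0.05 log units; within the scatter), so this read-out does not tell the two compounds apart. This is the first pair shown that isolates a change at this position: a ring with one nitrogen gives way to a ring of carbon only, a fluorine is present on both, and the step stays inside the usual spread of repeat measurements. Nothing measured here offers an explanation for this match.

Still open, from the compounds shown here alone, is how this assay would respond to a different kind of group at this position, such as an amine or a carboxylic acid. It is also unknown whether the same swap would give a similarly small step on the core of compound 2.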